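The source may hold more compounds than are shown below. What is called first, only, known or untested is meant among the compounds shown, and "the series" means these compounds.

Within an assay on HEK293 cells for displacement of a labelled ligand from NPC1-like intracellular cholesterol transporter 1 (Homo sapiens) (on this read-out higher numbers stand for weaker inhibition and lower numbers for stronger inhibition), compound 3 `CCC1CCCN(C(=O)CN2CN(c3ccccc3)C3(CCN(C(=O)c4ccc(C(C)(C)C)cc4)CC3)C2=O)C1` gives 3900 nM, the lowest of the two numbers available. Compound 1 `CC(C)(C)c1ccc(C(=O)N2CCC3(CC2)C(=O)N(CC(=O)N2CCN(S(C)(=O)=O)CC2)CN3c2ccccc2)cc1` gives 19000 nM in this assay, and the step of a 4.9-fold lower number from compound 1 to compound 3 (0.69 log units; beyond the scatter) is the only measured one in the set. Compound 2 `COC(=O)CCCNC(=O)CN1CN(c2ccccc2)C2(CCN(C(=O)c3ccc(C(C)(C)C)cc3)CC2)C1=O` carries no result in this assay, its entry being "not determined" (no result reported). Compound 4 `CC(C)(C)c1ccc(C(=O)N2CCC3(CC2)C(=O)N(CC(=O)N2CCCC(C(N)=O)C2)CN3c2ccccc2)cc1` differs from compound 3 by carbamoyl in place of ethyl on a saturated ring carbon. Within the data shown here, no measured step swaps a substituent on this ring; the step from compound 1 to compound 3 changed the whole amine and gives no direct guide. The expectation is therefore neutral, with no step beyond the scatter, and compound 4 is estimated at 6000 nM, in the range 2000 nM to 20000 nM, meaning an expected step of a 1.5-fold higher number from compound 3 to compound 4 (0.19 log units; within the scatter).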

Compound 4, half-maximal inhibitory concentration: 16900 nM
Estimate against measurement, compound 4: 2.8-fold (0.45 log units) below; the measured number falls inside the stated range.
By their numbers in this assay, from the lowest: compound 3; then compounds 4 and 1 (each within the scatter of the next).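

Within this series, the substituent on this saturated ring carbon matters: carbamoyl in place of ethyl gives a 4.3-fold higher number from compound 3 to compound 4 (0.64 log units; beyond the scatter), so the piperidine alone does not carry the better number of compound 3. The 3-carbamoylpiperidin-1-yl group also shows no separation from 4-(methylsulfonyl)piperazin-1-yl, with a 1.1-fold lower number from compound 1 to compound 4 (0.05 log units; within the scatter). No available data bear on the reason for the step from ethyl to carbamoyl.

Still open, from the compounds shown here alone, is how an unsubstituted piperidin-1-yl compares with the ethyl and carbamoyl groups. A propyl, a hydroxymethyl or a carboxylic acid on the same carbon also remains to be placed against them.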